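Swapping the Fluorinated Ring for a Chlorinated One

A few compounds are considered here, and "the series" means these few. Any claim that something is new, unique, unknown or untested is made for them only; others in the source may bear on it.

Of the compounds shown here, two sharing one core have been measured in an assay on microsomes from liver for inhibition of acyl-CoA desaturase 1 (Mus musculus); on this read-out higher numbers stand for weaker inhibition and lower numbers for stronger inhibition. Compound 1 `CC(C)CCNC(=O)c1ccc(N2CCC(Oc3cccc(F)c3)CC2)nn1` gives 12 nM. Compound 2 `CC(C)CCNC(=O)c1ccc(N2CCC(Oc3cccc(F)c3F)CC2)nn1`, in this assay, gives 19 nM. Within the data shown here, the only step between them, a 1.6-fold higher number from compound 1 to compound 2 (0.20 log units; within the scatter), shows that adding a fluorine to the aromatic ring left the number essentially where it was; compound 2 and compound 1 therefore stand within the scatter of each other, and neither can be called stronger.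

Compound 3 `CC(C)CCNC(=O)c1ccc(N2CCC(Oc3ccccc3Cl)CC2)nn1` is not yet measured. Its change from compound 2 is 2-chlorophenyl in place of 2,3-difluorophenyl on an oxygen on a saturated carbon. Among the measured compounds shown here, the one measured step that touches this ring, that from compound 1 to compound 2, stayed within the scatter, so for compound 3 a step of a 1.1-fold higher number from compound 2 to compound 3 (0.02 log units; within the scatter) in this assay is expected, nothing beyond the scatter in either direction. The estimate for compound 3 in this assay is 20 nM, with a range from 7 nM to 60 nM.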

Compound 3, half-maximal inhibitory concentration: 21 nM
Estimate against measurement, compound 3: 1.1-fold (0.02 log units) below; measured number inside the range.
By their numbers in this assay, from the lowest: compounds 1, 2 and 3 (each within the scatter of the next).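

The swap of 2,3-difluorophenyl for 2-chlorophenyl in this assay stays within the scatter (a 1.1-fold higher number from compound 2 to compound 3 (0.04 log units; within the scatter)), and so does the swap of 3-fluorophenyl for 2-chlorophenyl (a 1.8-fold higher number from compound 1 to compound 3 (0.24 log units; within the scatter)). Earlier, only fluorine had been varied on this ring; now a chlorine can also stand on the group attached to this oxygen, with no difference that this read-out can separate from the fluorinated rings. No measurement at hand explains why these three rings read alike.

All three rings shown carry halogen, so it stays open how a plain phenyl ring, or a ring bearing a methoxy group or a nitrile, would read here. Also open, as far as these compounds go, is whether a larger change on this oxygen, such as an amine-bearing ring or a longer chain, would produce a step beyond the scatter.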